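Adding Fluoro to Compound 1: What to Expect

The compounds below may be only part of what the source reports. "The series", "measured", "known", "first", "only" and "open" are said of these compounds alone.

Compound 1, `Nc1cc(=O)[nH]c(=O)n1[C@@H]1O[C@H](CO)[C@@H](O)[C@H]1O`, gives only an assay limit of > 50000 nM in a functional assay on OCI-AML2 cells (Homo sapiens) for antiproliferative activity, read by WST assay, with a stated time of 3 days; on this read-out higher numbers stand for weaker inhibition and lower numbers for stronger inhibition.
Compound 2, `CN(C)c1cc(=O)[nH]c(=O)n1[C@@H]1O[C@H](CO)[C@@H](O)[C@H]1O`, gives only an assay limit of > 50000 nM in this assay .
Compound 3, `O=Cc1cc(=O)[nH]c(=O)n1[C@@H]1O[C@H](CO)[C@@H](O)[C@H]1O`, gives only an assay limit of > 50000 nM in this assay .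

Compound 1 therefore stands nowhere in particular on these numbers: its result is a limit, not a measured value, and it shares that position with the other two, as shown by the limit of > 50000 nM in this assay, at which 3 of the 3 values shown sit. The steps among the measured compounds are a step that the two limits leave unreadable from compound 1 to compound 2, a step that the two limits leave unreadable from compound 1 to compound 3 and a step that the two limits leave unreadable from compound 2 to compound 3, so none of them reveals how much any change at the amino-bearing carbon matters.

Compound 4, `Nc1c(F)c(=O)[nH]c(=O)n1[C@@H]1O[C@H](CO)[C@@H](O)[C@H]1O`, differs from compound 1 by fluoro in place of hydrogen on an aromatic carbon. Among the measured compounds shown here, no measured step involves this fluoro change, and none of the measured steps is readable in size or direction, so there is no basis for expecting movement beyond the scatter.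

Compound 4 is therefore expected to give around 60000 nM in this assay , with a range of 15000 nM to 200000 nM, most likely reported as a limit again. This expectation corresponds to a step that the limit leaves unreadable from compound 1 to compound 4.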

Compound 4, half-maximal inhibitory concentration: 900 nM
For compound 4 the middle estimate is 67-fold (1.82 log units) above the measured one, outside the stated range (below it).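

In this assay, fluoro in place of hydrogen on this aromatic carbon, ortho to the amino group, gives an at least 55-fold lower number from compound 1 to compound 4 (1.74 log units; beyond the scatter), so a change at this position can move the read-out by a large amount. The steps among compound 1, compound 2 and compound 3 cannot be read, and they gave no sign of this. Compound 4 is the only compound shown with a measured value rather than a limit: the limit of > 50000 nM in this assay, at which 3 of the 4 values shown sit.

Only hydrogen and fluoro are shown at this carbon, so it remains open whether chloro, methyl or a nitrile there would give a step of similar size. On these data alone, it also remains open whether fluoro gives such a step when the amino group is replaced by dimethylamino or formyl.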